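Swapping a Hydroxyl Tail for a Methylamino Tail

A few compounds are considered here, and "the series" means these few. Any claim that something is new, unique, unknown or untested is made for them only; others in the source may bear on it.

Of the compounds shown here, two from this series have been tested in a functional assay on HeLa cells (Homo sapiens) for antiproliferative activity; a lower number here means a stronger inhibitor, a higher number a weaker inhibitor. Compound 1, `CO/N=C/c1c(N)ncnc1Oc1ccc2cccnc2c1`, gives 1820 nM in this assay. Compound 2, `Cc1cc2c(F)c(Oc3ncnc(N)c3/C=N/OCCCO)ccc2[nH]1`, gives 362 nM in this assay, the lower of the two numbers and therefore the stronger inhibitor among them, with compound 1 sitting beyond the usual scatter above it. The next compound, compound 3, `CNCCO/N=C/c1c(N)ncnc1Oc1ccc2[nH]c(C)cc2c1F`, differs from compound 2 in one spot: methylamino in place of hydroxymethyl on a saturated chain carbon, two bonds along the chain from an oxygen. Among the measured compounds shown here, no pair of measured compounds shows this exact change, so the size of the effect cannot be read from the data. The tail sits far from the shared core, and the change keeps the count of donors and acceptors, so the step is expected to be small, a 1.6-fold lower number from compound 2 to compound 3 (0.22 log units; within the scatter), leaning toward a slightly stronger inhibitor. Compound 3 is therefore estimated at 220 nM in this assay, within a range from 70 nM to 700 nM.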

Compound 3, half-maximal inhibitory concentration: 2010 nM
Beside the measured number, compound 3's estimate is 9.1-fold (0.96 log units) below it, outside the stated range (above it).
By their numbers in this assay, from the lowest: compound 2; then compounds 1 and 3 (each within the scatter of the next).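

Until now, nothing showed whether the far end of this tail mattered. Methylamino in place of hydroxymethyl, on a saturated chain carbon two bonds along the chain from an oxygen, gives a 5.6-fold higher number from compound 2 to compound 3 (0.74 log units; beyond the scatter) in this assay. So this position is sensitive to what sits on it: the swap leaves the counts of heavy atoms, donors and acceptors unchanged, yet the number still moves beyond the scatter, and nothing available here accounts for that shift.

As far as these compounds go, with only these two tail ends in hand, it remains open whether the hydroxyl of compound 2 is especially favourable or the methylamino of compound 3 is especially unfavourable. A tail ending in a methoxy group, a dimethylamino group or a carboxylic acid, or a longer chain ending in the same groups, would help separate these two readings.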